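From Isobutyl to 3-Methylphenyl on an Aromatic Nitrogen

This account rests on a few compounds, and the source may have more. Where it says the series, first, only, none or still open, it means among the compounds named here.

In a functional assay on HT-29 cells (Homo sapiens) for antiproliferative activity, read by MTT assay, with a stated time of 72 h (a lower number here means a stronger inhibitor, a higher number a weaker inhibitor), compound 1 `CCn1ccnc1-c1cc(OC)c(OC)c(OC)c1` gives > 100000 nM, which is a limit and not a number. Compound 2 `COc1cc(-c2nccn2C(C)C)cc(OC)c1OC` gives > 100000 nM, also a limit. Compound 3 `COc1cc(-c2nccn2CC(C)C)cc(OC)c1OC` gives > 100000 nM, again a limit. Compound 3 therefore stands with the other two: the limit of > 100000 nM in this assay, at which 3 of the 3 values shown sit.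

Putting 3-methylphenyl in place of isobutyl on an aromatic nitrogen gives compound 4 `COc1cc(-c2nccn2-c2cccc(C)c2)cc(OC)c1OC`: 3-methylphenyl in place of isobutyl on an aromatic nitrogen.

Within the data shown here, three measured steps bear on this change: a step that the two limits leave unreadable from compound 1 to compound 2, a step that the two limits leave unreadable from compound 1 to compound 3 and a step that the two limits leave unreadable from compound 2 to compound 3. None has a readable size, and all involve only open chains, so the estimate is loose.

The expected change, toward a stronger inhibitor, is an at least 12-fold lower number from compound 3 to compound 4 (1.09 log units; beyond the scatter). Compound 4 is estimated at 8000 nM, with an expected range of 300 nM to 100000 nM.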

Compound 4, half-maximal inhibitory concentration: 14600 nM
Compound 4: middle estimate off by 1.8-fold (0.26 log units), on the low side; the range from low to high includes it.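

In this assay compound 4 is the only compound shown with a readable number, which sets 3-methylphenyl on this nitrogen apart from the open chains ethyl, isopropyl and isobutyl, whose steps among themselves cannot be read. The change gives an at least 6.8-fold lower number from compound 3 to compound 4 (0.83 log units; beyond the scatter), and likewise an at least 6.8-fold lower number from compound 2 to compound 4 (0.83 log units; beyond the scatter) and an at least 6.8-fold lower number from compound 1 to compound 4 (0.83 log units; beyond the scatter). The open-chain compounds share a limit, not a number: the limit of > 100000 nM in this assay, at which 3 of the 4 values shown sit.

Whether the ring or its methyl accounts for this step stays open, and plain phenyl would help to separate the two. Cyclohexyl would ask whether the ring must be aromatic.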